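The compounds below may be only part of what the source reports. "The series", "measured", "known", "first", "only" and "open" are said of these compounds alone.

In a functional assay on HeLa cells (Homo sapiens) for antiproliferative activity, read by MTT assay, with a stated time of 24 h (on this read-out lower numbers stand for stronger inhibition and higher numbers for weaker inhibition), compound 1 `c1ccc(CSc2nnc(-c3ccc4c(c3)OCCO4)n2-c2ccccc2)cc1` gives 32800 nM while compound 2 `Clc1ccccc1CSc1nnc(-c2ccc3c(c2)OCCO3)n1-c1ccccc1` gives 29000 nM and compound 3 `Fc1ccccc1CSc1nnc(-c2ccc3c(c2)OCCO3)n1-c1ccccc1` gives 24300 nM so the three values lie within the scatter of one another, and compound 2 stands apart from neither. Compound 4 `Fc1ccc(CSc2nnc(-c3ccc4c(c3)OCCO4)n2-c2ccccc2)cc1` differs from compound 2 by 4-fluorophenyl in place of 2-chlorophenyl on a saturated chain carbon bound to a sulfur with 4-fluorophenyl in place of 2-chlorophenyl on a saturated chain carbon bound to a sulfur. Among the compounds with values here, the steps that bear on this are a 1.1-fold lower number from compound 1 to compound 2 (0.05 log units; within the scatter) and a 1.3-fold lower number from compound 1 to compound 3 (0.13 log units; within the scatter) and a 1.2-fold lower number from compound 2 to compound 3 (0.08 log units; within the scatter) all within the scatter, though no measured compound carries 4-fluorophenyl. Expected in this assay is no step beyond the scatter, with an estimated 1.1-fold lower number from compound 2 to compound 4 (0.03 log units; within the scatter) as the likely size. Compound 4 is expected at 27000 nM (estimated range 15000 nM to 45000 nM)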

Compound 4, half-maximal inhibitory concentration: 46900 nM
Estimate against measurement, compound 4: 1.7-fold (0.24 log units) below, and the stated range ends below it.
By their numbers in this assay, from the lowest: compounds 3, 2, 1 and 4 (each within the scatter of the next).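

In this assay the 4-fluorophenyl group on a saturated chain carbon bound to a sulfur gives a 1.6-fold higher number from compound 2 to compound 4 (0.21 log units; within the scatter) and a 1.9-fold higher number from compound 3 to compound 4 (0.29 log units; within the scatter) and a 1.4-fold higher number from compound 1 to compound 4 (0.16 log units; within the scatter) and so stays within the scatter of every earlier compound. Having 4-fluorophenyl in place of 2-fluorophenyl therefore separates nothing here, and all four groups at this place read alike. No measurement at hand bears on these steps. From the compounds shown here alone, whether an amine, a carboxylic acid or a longer chain at this place would give a step beyond the scatter stays open. Going by these compounds, whether this flat picture holds on another core or in another read-out also stays open.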